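Benzothiophene replaces quinoline on the amide carbonyl

This account rests on a few compounds, and the source may have more. Where it says the series, first, only, none or still open, it means among the compounds named here.

Compound 2 `N=C(N)NCCC[C@@H](NC(=O)c1ccnc2ccccc12)C(=O)NCc1ccc(C(F)(F)F)cc1` and compound 1 `N=C(N)NCCC[C@@H](NC(=O)c1ccc(F)c2ccccc12)C(=O)NCc1ccc(C(F)(F)F)cc1` share one core and differ only in the aryl group on the carbonyl carbon. In a functional assay on HEK293 cells for antagonist activity at melanin-concentrating hormone receptor 1 (Homo sapiens) (a lower number here means a stronger inhibitor, a higher number a weaker inhibitor), compound 1 gives 311 nM, while compound 2 gives 1030 nM, the highest of the two numbers shown; the single step is a 3.3-fold higher number from compound 1 to compound 2 (0.52 log units; beyond the scatter). Compound 3 `N=C(N)NCCC[C@@H](NC(=O)c1csc2ccccc12)C(=O)NCc1ccc(C(F)(F)F)cc1` has not yet been measured in this assay. It differs from compound 2 in one place: 1-benzothiophen-3-yl in place of quinolin-4-yl on a carbonyl carbon. Among the measured compounds shown here, the only step that bears on this change is the one from compound 1 to compound 2, in which a group with one six-membered aromatic ring of carbon only and a second six-membered aromatic ring with one hetero atom gave way to quinolin-4-yl. The entering 1-benzothiophen-3-yl again carries a six-membered aromatic ring of carbon only, beside a five-membered aromatic ring with one hetero atom, so a partial return toward the number of compound 1 is expected, of about a 2.3-fold lower number from compound 2 to compound 3 (0.36 log units; beyond the scatter). For compound 3 the expected value in this assay is 450 nM, with a range from 150 nM to 1300 nM.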

Compound 3, half-maximal inhibitory concentration: 952 nM
Estimate against measurement, compound 3: 2.1-fold (0.33 log units) below; measured number inside the range.
By their numbers in this assay, from the lowest: compound 1; then compounds 3 and 2 (each within the scatter of the next).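

In this assay, 1-benzothiophen-3-yl and quinolin-4-yl on the carbonyl carbon cannot be told apart, with a 1.1-fold lower number from compound 2 to compound 3 (0.03 log units; within the scatter), so a five-membered aromatic ring with a sulfur atom and a six-membered aromatic ring with a nitrogen atom serve alike in this comparison. Against the group of compound 1, the new group gives a 3.1-fold higher number from compound 1 to compound 3 (0.49 log units; beyond the scatter), and this step, like a 3.3-fold higher number from compound 1 to compound 2 (0.52 log units; beyond the scatter), lies beyond the scatter; among these three compounds, then, both groups carrying a ring with a hetero atom give higher numbers than 4-fluoronaphthalen-1-yl, and no compound shown goes against this. Nothing measured here accounts for that difference.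

The compounds shown leave open whether the lower number of compound 1 goes with its fluorine or with its second ring of carbon only, since 4-fluoronaphthalen-1-yl differs from the other two groups in both respects. A plain naphthalen-1-yl group would separate these two features, and a 1H-indol-3-yl or 1-benzofuran-3-yl group would show whether the match between compound 2 and compound 3 extends to other hetero atoms in the ring.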